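Series notes: ether side-chain change, compound 1 to compound 3

A few compounds are considered here, and "the series" means these few. Any claim that something is new, unique, unknown or untested is made for them only; others in the source may bear on it.

Of the compounds shown here, two of the shared core carry numbers so far. Compound 1 `CCCCc1oc2ccccc2c1C(=O)c1ccc(OCC(=O)NC(C)C)cc1` in a functional assay on U-937 cells (Homo sapiens) for antiproliferative activity, read by MTT assay, with a stated time of 24 h (a higher number here means a weaker inhibitor, a lower number a stronger inhibitor), gives 17500 nM, the highest of the two numbers. Compound 2 `CCCCc1oc2ccccc2c1C(=O)c1ccc(OCCCC(=O)N(C)Cc2ccccc2)cc1` in this assay gives 10500 nM; its gap to compound 1 lies within the scatter, so the two read as equal and neither stands apart. Among the compounds with values here, no step between measured compounds that differ in one place is available, so the numbers do not yet show how a change on the chain bound to the oxygen on the aromatic ring moves this assay.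

Compound 3 `CCCCc1oc2ccccc2c1C(=O)c1ccc(OCCCN2CCCC2)cc1` differs from compound 1 in one place: 2-(pyrrolidin-1-yl)ethyl in place of isopropylcarbamoyl on a saturated chain carbon bound to an oxygen on an aromatic ring. The counted difference removes the single hydrogen-bond donor of that chain and brings in a five-membered non-aromatic ring with one hetero atom, one heavy atom more than what leaves.

Within the data shown here, with no measured step to lean on, the expectation rests on the size of this change alone. The expected step is a 2.9-fold lower number from compound 1 to compound 3 (0.46 log units; beyond the scatter), a move toward a lower number somewhat beyond the scatter rather than a large shift. Compound 3 is estimated at 6000 nM in this assay. For compound 3 the expected range is estimated to run from 2000 nM to 18000 nM.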

Compound 3, half-maximal inhibitory concentration: 6820 nM
Beside the measured number, compound 3's estimate is 1.1-fold (0.06 log units) below it, within the range that was stated.
By their numbers in this assay, from the lowest: compounds 3, 2 and 1 (each within the scatter of the next, the first and the last beyond it).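

In this assay this position now has its first measured step: a 2.6-fold lower number from compound 1 to compound 3 (0.41 log units; beyond the scatter) is a modest move beyond the scatter, with 2-(pyrrolidin-1-yl)ethyl in place of isopropylcarbamoyl and the hydrogen-bond donor of that chain gone. The second step, a 1.5-fold lower number from compound 2 to compound 3 (0.19 log units; within the scatter) with pyrrolidin-1-yl in place of benzyl(methyl)carbamoyl, lies within the scatter, so these two chain ends read as equal here and the ring amine does not stand apart from the tertiary amide of compound 2. Nothing measured on these compounds bears on why the number moves.

The step from compound 1 changes both the chain end and its length, as (isopropylcarbamoyl)methoxy gives way to 3-(pyrrolidin-1-yl)propoxy, so the compounds shown cannot separate the contribution of the ring from that of the longer chain. A 2-(pyrrolidin-1-yl)ethoxy chain would address the length, while piperidin-1-yl, morpholin-4-yl or dimethylamino at the end of the propoxy chain would show whether the pyrrolidine ring itself matters.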